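The source may hold more compounds than are shown below. What is called first, only, known or untested is meant among the compounds shown, and "the series" means these compounds.

Measured compounds:
compound 1 `CCCCc1cc2c(=O)cc(C)[nH]c2cc1OCCOc1ccccc1`: 28000 nM
compound 2 `CCc1c(C)[nH]c2cc(OCCOc3ccccc3)c(Br)cc2c1=O`: > 25000 nM
compound 3 `CCCCc1cc2c(=O)c(-c3ccc(COc4ccc(OC(F)(F)F)cc4)cc3)c(C)[nH]c2cc1OCCOc1ccccc1`: 16000 nM

In an ADME assay on J774 cells (Mus musculus) for antiproliferative activity, with a stated time of 72 h (a lower number here means that less compound is needed, a higher number that more compound is needed for the effect), compound 1 gives 28000 nM, the highest of the two numbers recorded in the series. The nearest is compound 3, which in this assay gives 16000 nM; that gap lies within the usual scatter, so the two compounds are not separated. Compound 2 gives only a limit in this assay, (the limit of > 25000 nM in this assay, at which 1 of the 3 values shown sits), and no number.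

Compound 4 `CCCCc1cc2c(=O)c(-c3ccc(C)cc3C)c(C)[nH]c2cc1OCCOc1ccccc1` is not yet measured. It differs from compound 1 in one place: 2,4-dimethylphenyl in place of hydrogen on an aromatic carbon. Going by the values given here, no measured pair shows the effect of this exact change. Among the compounds with values here, compound 3 is the one measured compound in which a substituent stands in place of hydrogen on an aromatic carbon of the shared core, and its value in this assay sits within the scatter of compound 1. On that basis the step of a 1.4-fold lower number from compound 1 to compound 4 (0.15 log units; within the scatter) is expected to be small, in the direction of a lower number if anything, and not beyond the scatter. Compound 4 is therefore expected to give about 20000 nM in this assay, with a range from 8000 nM to 50000 nM.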

Compound 4, half-maximal effective concentration: 22000 nM
For compound 4 the middle estimate is 1.1-fold (0.04 log units) below the measured one; low and high end bracket the measured number.
By their numbers in this assay, from the lowest: compounds 3, 4 and 1 (each within the scatter of the next).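

In this assay, going by these compounds alone, there is a 1.3-fold lower number from compound 1 to compound 4 (0.10 log units; within the scatter) when 2,4-dimethylphenyl, a six-membered aromatic ring of 8 heavy atoms, stands in place of hydrogen at this position, two atoms from the ring nitrogen and ortho to a methyl group; this is the first direct single-place reading of the change, and the added ring does not carry the number beyond the scatter. With the same position occupied by the larger aryl group of compound 3 at 16000 nM and by 2,4-dimethylphenyl in compound 4 at 22000 nM, the two values lie within the scatter of each other, so these two aryl groups are not separated in this assay. Nothing at hand bears on a cause for this step.

From the compounds shown here alone, whether any group at this position moves the number beyond the scatter stays open, for example a carboxylic acid or an amine on the added ring. The compounds shown also give no single-place step at any other place on the shared core, so the effect of a longer chain there remains unknown.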